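Swapping ethyl for phenyl on the carbonyl carbon

This account rests on a few compounds, and the source may have more. Where it says the series, first, only, none or still open, it means among the compounds named here.

Compound 1 `CCC(=O)c1ccc2c(c1)sc(=O)n2CCN1CCCC1`: 13.9 mg/kg
Compound 2 `CCC(=O)c1ccc2c(c1)sc(=O)n2CCN(C)C`: 21.8 mg/kg
Compound 3 `CCC(=O)c1ccc2c(c1)sc(=O)n2CCN1CCCCC1`: 8.7 mg/kg

All three values come from a functional assay on the whole organism with Mus musculus as the target, in the maximal electroshock model; on this read-out higher numbers stand for an effect only at larger amounts of compound and lower numbers for an effect already at smaller amounts. Compound 1 cannot be separated from either of the others, as a 1.6-fold higher number from compound 1 to compound 2 (0.20 log units; within the scatter) and a 1.6-fold lower number from compound 1 to compound 3 (0.20 log units; within the scatter) show. Only the remaining pair differs clearly, with a 2.5-fold lower number from compound 2 to compound 3 (0.40 log units; beyond the scatter).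

Compound 4 `O=C(c1ccccc1)c1ccc2c(c1)sc(=O)n2CCN1CCCC1` keeps the core and the pyrrolidin-1-yl of compound 1 but changes the other end: phenyl in place of ethyl on a carbonyl carbon. Put simply, propanoyl becomes benzoyl.

Among the compounds with values here, all the measured steps exchange dimethylamino, pyrrolidin-1-yl and piperidin-1-yl on a saturated chain carbon. None touches the carbonyl carbon, so the data give no direct guide to this change, or to its direction. Within the data shown here, they show only that the largest step so far is modest, a 2.5-fold lower number from compound 2 to compound 3 (0.40 log units; beyond the scatter). No shift beyond the scatter is therefore expected, though the uncertainty is wide.

The expected change is a 1.2-fold higher number from compound 1 to compound 4 (0.06 log units; within the scatter).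

For compound 4 the estimate is 16 mg/kg, with an expected range from 6 mg/kg to 45 mg/kg.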

Compound 4, dose for half-maximal effect: 42.5 mg/kg
For compound 4 the middle estimate is 2.7-fold (0.42 log units) below the measured one; the range from low to high includes it.
By their numbers in this assay, from the lowest: compounds 3, 1, 2 and 4 (each within the scatter of the next, the first and the last beyond it).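

In this assay the carbonyl end of the molecule turns out to matter, which the earlier amine exchanges could not show: phenyl in place of ethyl on a carbonyl carbon gives a 3.1-fold higher number from compound 1 to compound 4 (0.49 log units; beyond the scatter) and lies beyond the usual scatter. For this pair, which shares the pyrrolidin-1-yl group, benzoyl therefore needs larger amounts than propanoyl to reach the same effect in mice. No measurement shown here offers an explanation for this shift.

This single pair leaves open whether the same swap would shift the number as far with piperidin-1-yl or dimethylamino at the other end. Methyl, butyl or cyclohexyl on the carbonyl carbon would help show whether the shift follows the ring itself or simply the larger number of carbons.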